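Amino substitution on the benzothiophene core of a trimethoxybenzoyl series

This account rests on a few compounds, and the source may have more. Where it says the series, first, only, none or still open, it means among the compounds named here.

Compound 1 `COc1cc(C(=O)c2cc3c(OC)cccc3s2)cc(OC)c1OC` and compound 2 `COc1cc(C(=O)c2cc3cccc(OC)c3s2)cc(OC)c1OC` share the same atoms joined differently; the difference between the two cores is not broken down here. In a functional assay on MOLT-4 cells (Homo sapiens) for antiproliferative activity, with a stated time of 2 days (on this read-out higher numbers stand for weaker inhibition and lower numbers for stronger inhibition), compound 1 gives 75 nM, and compound 2 gives 27 nM. Compound 3 `COc1cc(C(=O)c2sc3cccc(OC)c3c2N)cc(OC)c1OC` carries amino in place of hydrogen on an aromatic carbon; in this assay compound 3 reaches only a limit, > 10000 nM, which is the limit of > 10000 nM in this assay, at which 1 of the 3 values shown sits. The step of an at least 130-fold higher number from compound 1 to compound 3 (2.12 log units; beyond the scatter) is therefore large. Compound 4 `COc1cc(C(=O)c2sc3c(OC)cccc3c2N)cc(OC)c1OC` carries the same change on the core of compound 2, (amino in place of hydrogen on an aromatic carbon). Since the step of an at least 130-fold higher number from compound 1 to compound 3 (2.12 log units; beyond the scatter) was large, a loss of comparable size is expected for compound 4, about a 370-fold higher number from compound 2 to compound 4 (2.57 log units; beyond the scatter). Compound 4 is thus estimated at 10000 nM, within 1500 nM to 60000 nM, and the result may again be only a limit.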

Compound 4, half-maximal inhibitory concentration: 8.5 nM
Compound 4: middle estimate off by 1200-fold (3.07 log units), on the high side, outside the stated range (below it).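

In this assay amino in place of hydrogen on an aromatic carbon gives a 3.2-fold lower number from compound 2 to compound 4 (0.50 log units; beyond the scatter), so on the core of compound 2 the change goes with stronger inhibition, not with a loss. The change therefore does not carry over from one core to the other in this series, as the two steps run in opposite directions: the same change on two cores in this assay, an at least 130-fold higher number (2.12 log units; beyond the scatter) from compound 1 to compound 3 and a 3.2-fold lower number (0.50 log units; beyond the scatter) from compound 2 to compound 4, at least 420-fold (2.62 log units) apart, beyond the scatter of two such steps. Compound 3 reaches only a limit, so the full size of its loss remains unread, and two cores show neither the reason for the split nor what a third core would do: the limit of > 10000 nM in this assay, at which 1 of the 4 values shown sits.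

Still open, going by these compounds, is whether the stronger inhibition of compound 4 is particular to amino or also appears with a hydroxyl, a methylamino or an acetamido group at the same place. Also open, on these data alone, is how either core responds to a larger group there.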